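The compounds below may be only part of what the source reports. "The series", "measured", "known", "first", "only" and "open" are said of these compounds alone.

Measured in an assay on isolated protein for displacement of a labelled ligand from metabotropic glutamate receptor 5 (Homo sapiens), with a stated time of 60 min, tested at 1 uM; on this read-out lower numbers stand for less inhibition and higher numbers for more inhibition at the one concentration tested (going by the name of the read-out):
compound 1 `Cc1cc(C)cc(S(=O)(=O)c2cnc3ccc(C)cc3c2N2CCC(C)CC2)c1`, 80%
compound 2 `COc1ccc2ncc(S(=O)(=O)c3cc(C)cc(C)c3)c(N3CCC(C)CC3)c2c1`, 79%
compound 3 `Cc1cc(C)cc(S(=O)(=O)c2cnc3ccc(Cl)cc3c2N2CCC(C)CC2)c1`, 49%

Compound 1 gives the highest number of the three; compound 2 sits within the scatter of it (a number 1 percentage points lower from compound 1 to compound 2 (within the scatter)), while compound 3 lies well below (a number 31 percentage points lower from compound 1 to compound 3 (beyond the scatter), and a number 30 percentage points lower from compound 2 to compound 3 (beyond the scatter)). Compound 4 `Cc1ccc2ncc(S(=O)(=O)c3ccccc3)c(N3CCC(C)CC3)c2c1` keeps the core of compound 1 and changes only the group on the sulfonyl sulfur: phenyl in place of 3,5-dimethylphenyl on a sulfonyl sulfur. Within the data shown here, none of the measured steps touches this group; all three vary the substituent on the core, so no step bears directly on the change. The expectation for this assay is therefore a guess: a drop of some size beyond the scatter is expected, a number 22 percentage points lower from compound 1 to compound 4 (beyond the scatter). Compound 4 is estimated at 58%, range 30% to 82%.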

Compound 4, a percentage reported as inhibition, at one concentration (the size of the read-out at that concentration, not a potency): 67%
Estimate against measurement, compound 4: 9 percentage points below; measured number inside the range.
By their numbers in this assay, from the lowest: compound 3; then compound 4; then compounds 2 and 1 (each within the scatter of the next).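

In this assay, the group on the sulfonyl sulfur proves to matter: phenyl in place of 3,5-dimethylphenyl gives a number 13 percentage points lower from compound 1 to compound 4 (beyond the scatter). This is the only step shown at this position, and its modest size means that removing both methyl groups does not abolish the inhibition seen at the one concentration tested. Nothing available accounts for the size of this step.

From the compounds shown here alone, whether a single methyl group, as in 3-methylphenyl, would be enough remains open. Also open, going by these compounds, are how 3,5-dichlorophenyl or a pyridyl ring on the sulfonyl sulfur would read, and whether this step carries over to compound 2 and compound 3.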